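Cyclopentyl in Place of Phenyl: a Cytotoxicity Step

This account rests on a few compounds, and the source may have more. Where it says the series, first, only, none or still open, it means among the compounds named here.

Among the compounds with values here, the shared core appears in compound 1 `CCc1cnc(NC(=O)C2CCCCC2)s1` and compound 2 `O=C(Nc1ncc(Cc2ccccc2)s1)C1CCCCC1`, the two measured members of the set. In an ADME assay on P388D1 cells (Mus musculus) for cytotoxicity, read by fluorescence and resazurin assay, with a stated time of 72 h (on this read-out higher numbers stand for weaker inhibition and lower numbers for stronger inhibition), compound 1 gives "not determined" (no result reported). In this assay compound 2 gives only a limit, > 40000 nM, so no single number stands for it. Within the data shown here, compound 2 therefore sits at the limit of > 40000 nM in this assay, at which 1 of the 2 values shown sits, and there is no step between measured compounds to lean on. Compound 3 `O=C(Nc1ncc(CC2CCCC2)s1)C1CCCCC1` is yet to be tested in this assay; it differs from compound 2 in one place, (cyclopentyl in place of phenyl on a saturated chain carbon bound to an aromatic carbon). Among the measured compounds shown here, with no measured step to guide the size of this change, the expectation is a step that the limit leaves unreadable from compound 2 to compound 3 that stays within the scatter, in no firm direction. Compound 3 is thus expected to give 60000 nM in this assay, within a range of 25000 nM to 200000 nM, most likely again reported only as a limit.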

Compound 3, half-maximal inhibitory concentration: > 40000 nM
Compound 3 was reported as a limit; the forecaster's own chance of this, stated with the estimate: 80%; the middle value lies beyond the limit too.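

In this assay compound 2 and compound 3 are both reported only as limits, so no step can be read between them. The compounds shown leave open whether cyclopentyl in place of phenyl changes the cytotoxicity at all, and in which direction.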